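Acetoxy to hydroxy, carried from one core to another

The source may hold more compounds than are shown below. What is called first, only, known or untested is meant among the compounds shown, and "the series" means these compounds.

Compound 1 `COc1ccc([C@@H]2Cc3cc(OC)ccc3N(C[C@@H]3CCCN3)C(=O)[C@@H]2OC(C)=O)cc1`: in a functional assay (aorta) with Oryctolagus cuniculus as the target (a higher number here means a weaker inhibitor, a lower number a stronger inhibitor), compound 1 gives 230 nM.
Compound 2 `COc1ccc([C@@H]2Sc3cc(OC)ccc3N(C[C@@H]3CCCN3)C(=O)[C@@H]2OC(C)=O)cc1`: in this assay compound 2 gives 120 nM.
Compound 3 `COc1ccc([C@@H]2Cc3cc(OC)ccc3N(C[C@@H]3CCCN3)C(=O)[C@@H]2O)cc1`: in this assay compound 3 gives 1120 nM.

Compound 3 is compound 1 after a single change, (hydrogen in place of acetyl on an oxygen on a saturated carbon). That change produced a 4.9-fold higher number from compound 1 to compound 3 (0.69 log units; beyond the scatter). Compound 2 differs from compound 1 in the core; that difference is not broken down here, and the two values lie within the usual scatter of each other. Compound 4 `COc1ccc([C@@H]2Sc3cc(OC)ccc3N(C[C@@H]3CCCN3)C(=O)[C@@H]2O)cc1` is compound 2 after the same change, (hydrogen in place of acetyl on an oxygen on a saturated carbon), at a place described in the same words as before. Among the measured compounds shown here, only one earlier instance of this change is in hand, so the expectation rests on it alone. Compound 4 is expected to show a 4.9-fold higher number from compound 2 to compound 4 (0.69 log units; beyond the scatter) in this assay because the same change already gave a 4.9-fold higher number from compound 1 to compound 3 (0.69 log units; beyond the scatter). The estimate for compound 4 is therefore 590 nM, with a likely span from 250 nM to 1400 nM.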

Compound 4, half-maximal inhibitory concentration: 370 nM
Beside the measured number, compound 4's estimate is 1.6-fold (0.20 log units) above it; the range from low to high includes it.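

In this assay, acetoxy to hydroxy on the second core gives a 3.1-fold higher number from compound 2 to compound 4 (0.49 log units; beyond the scatter), so the change keeps its direction when carried over. The two steps do not differ in size on this evidence: the same change on two cores in this assay, a 4.9-fold higher number (0.69 log units; beyond the scatter) from compound 1 to compound 3 and a 3.1-fold higher number (0.49 log units; beyond the scatter) from compound 2 to compound 4, 1.6-fold (0.20 log units) apart, within the scatter of two such steps. This covers only the core of compound 1 and the core of compound 2; it gives no general rule for other cores and no explanation of the step.

Still open, on these data alone, is how the two cores would respond to other groups on that oxygen, such as a longer acyl chain or a methyl ether. As far as these compounds go, it is also open whether such groups would keep the two cores in step as acetoxy and hydroxy do.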